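The source may hold more compounds than are shown below. What is called first, only, known or untested is meant among the compounds shown, and "the series" means these compounds.

Measured in a functional assay on DU-145 cells (Homo sapiens) for inhibition, read by trypan blue exclusion, with a stated time of 96 h; a higher number here means a weaker inhibitor of growth, a lower number a stronger inhibitor of growth:

- compound 1 `Cc1ccc(S(=O)(=O)/C(=C/c2ccc(Cl)cc2)C(=O)c2ccc(Cl)cc2)cc1`: 1000 nM
- compound 2 `Cc1ccc(S(=O)(=O)/C(=C/c2ccc(Oc3ccccc3)cc2)C(=O)c2ccc(Cl)cc2)cc1`: 1000 nM
- compound 3 `Cc1ccc(CS(=O)(=O)/C(=C/c2ccc(Cl)cc2)C(=O)c2ccc(Cl)cc2)cc1`: 25000 nM

Compound 1 stands level with compound 2, the two together giving the lowest numbers of the three in this assay; its furthest neighbour is compound 3, as the step of a 25-fold higher number from compound 1 to compound 3 (1.40 log units; beyond the scatter) shows. The step of no change at the digits printed from compound 1 to compound 2 (within the scatter) shows that replacing the chloro on the aromatic carbon with phenoxy leaves the number where it was.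

Compound 4 `Cc1ccc(S(=O)(=O)/C(=C/c2c(O)cc(O)cc2O)C(=O)c2ccc(Cl)cc2)cc1` differs from compound 1 at a single place: 2,4,6-trihydroxyphenyl in place of 4-chlorophenyl on a double-bonded chain carbon bound to a double-bonded chain carbon. The step from compound 1 to compound 2 bears most directly on this, since it also alters the same aromatic ring and produced no change beyond the scatter. The step from compound 1 to compound 3 concerns the sulfonyl sulfur and so speaks little to the change in hand. Compound 4 is therefore expected to sit close to compound 1, with the step of a 1.5-fold higher number from compound 1 to compound 4 (0.18 log units; within the scatter) anticipated to be small, if anything a little toward a higher number. The estimate for compound 4 in this assay is 1500 nM, within the range 300 nM to 8000 nM.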

Compound 4, concentration for 50% growth inhibition: > 100000 nM
Compound 4 gave a limit, no number; the forecaster's own chance of this, stated with the estimate: 10%; at least 66-fold (1.82 log units) between middle value and limit.
By their numbers in this assay, from the lowest: compounds 1 and 2 (each within the scatter of the next); then compound 3. At a limit, above all of these: compound 4.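

In this assay compound 4 gives > 100000 nM, which is a limit of the assay and not a number. The earlier compounds shown here showed this position only through the step of no change at the digits printed from compound 1 to compound 2 (within the scatter), and the new step of an at least 100-fold higher number from compound 1 to compound 4 (2.00 log units; beyond the scatter) shows that the number here does not stay put for every group that enters. A change at this place can thus weigh at least as heavily as the change on the sulfonyl sulfur, the step of a 25-fold higher number from compound 1 to compound 3 (1.40 log units; beyond the scatter).

All the hydroxy groups of the 2,4,6-trihydroxyphenyl enter together, so the compounds shown cannot tell whether the result belongs to one of them, to their number or to the whole pattern. Also open, as far as these compounds go, is how a single hydroxy, a methoxy or an amine on this ring would stand.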